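The source may hold more compounds than are shown below. What is called first, only, known or untested is meant among the compounds shown, and "the series" means these compounds.

Working notes on the series. Compound 1 `NC(=O)C[C@H](NC(=O)c1ccc(C#Cc2ccccc2)cc1)C(=O)NO` gives 61000 nM in a physicochemical assay for solubility; a lower number here means a less soluble compound, a higher number a more soluble compound. Compound 2 `CC(C)(NC(=O)c1ccc(C#Cc2ccccc2)cc1)C(=O)NO` gives 182000 nM in this assay, so compound 1 stands lowest of the two numbers, with compound 2 its nearest neighbour at a gap beyond the scatter. Within the data shown here, no pair of measured compounds differing in one place is recorded, so only the two values themselves are known and no measured step can be drawn from them.

Compound 3 `C#CCNC(=O)C[C@H](NC(=O)c1ccc(C#Cc2ccccc2)cc1)C(=O)NO` has not yet been measured in this assay. Compared with compound 1 the change is propargyl in place of hydrogen on an amide-type nitrogen. Nothing in the measured pair speaks directly to this change, since compound 2 differs from compound 1 elsewhere. The step from compound 1 to compound 3 is expected to be a 2.0-fold lower number from compound 1 to compound 3 (0.31 log units; beyond the scatter), a decrease somewhat beyond the scatter in this assay. On that basis compound 3 is estimated at 30000 nM in this assay, with a range from 10000 nM to 90000 nM. A result within the scatter of compound 1 would not be surprising.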

Compound 3, solubility: 8000 nM
The estimate for compound 3 lay 3.8-fold (0.57 log units) above the measured number; the measured number lies below the stated range.
By their numbers in this assay, from the lowest: compound 3; then compound 1; then compound 2.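

Propargyl in place of hydrogen on the amide-type nitrogen gives a 7.6-fold lower number from compound 1 to compound 3 (0.88 log units; beyond the scatter) in this assay as the first measured step in the series, which shows that the read-out moves beyond the scatter when this hydrogen is replaced. Since the rest of compound 3 matches compound 1, this step can be tied to this one place on the molecule, something the two earlier values could not do. No measurement at hand bears on why the number falls with this group, so the step stands as an observation from a single pair.

On these data alone, whether the fall follows from the triple bond, from the added carbon chain or from the replacement of the amide hydrogen as such stays open, and a methyl or an n-propyl group on the same nitrogen would separate these readings. Also open, as far as these compounds go, is whether a chain ending in an amine or a carboxylic acid on this nitrogen would move the number in the same direction or in the opposite one.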